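Para-bromo analogue of a benzoyl amidine: expected writhing dose

This account rests on a few compounds, and the source may have more. Where it says the series, first, only, none or still open, it means among the compounds named here.

Compound 1, `O=C(/N=C1\NC2(CCCCO2)CCS1)Nc1ccccc1`, in a functional assay on the whole organism (strain CF-1) with Mus musculus as the target, in the writhing test, with a stated time of 15 min (a higher number here means that more compound is needed for the effect, a lower number that less compound is needed), gives only a limit, > 200 mg/kg.
Compound 2, `O=C(/N=C1\NC2(CCCCO2)CCS1)c1ccccc1`, in this assay gives 5 mg/kg.
Compound 3, `O=C(/N=C1\NC2(CCCCO2)CCS1)c1ccc(F)cc1`, in this assay gives three entries, 8.8 mg/kg; 28 mg/kg; 49 mg/kg (3 entries).

Going by the values given here, compound 2 holds the only single number in this assay; compound 1 shows a limit, and compound 3 shows three separate entries rather than one figure. Among the compounds with values here, the one measured step, an at least 40-fold lower number from compound 1 to compound 2 (1.60 log units; beyond the scatter), concerns the group on the carbonyl carbon and does not touch the ring where compound 4 differs.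

Compound 4, `O=C(/N=C1\NC2(CCCCO2)CCS1)c1ccc(Br)cc1`, differs from compound 2 by bromo in place of hydrogen on an aromatic carbon. Within the data shown here, no measured step covers this kind of change directly. Compound 3 carries a fluoro at that same place, and its three entries, (the several entries of compound 3 in this assay, 8.8 mg/kg; 28 mg/kg; 49 mg/kg (3 entries)), spread widely, with the lowest of them close to the number for compound 2 and the others higher. On that basis compound 4 is expected to sit near or somewhat above compound 2, with a step of a 3.0-fold higher number from compound 2 to compound 4 (0.48 log units; beyond the scatter). The estimated value for compound 4 in this assay is 15 mg/kg, with a range from 4 mg/kg to 60 mg/kg.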

Compound 4, dose for half-maximal effect: > 200 mg/kg
Compound 4 was reported as a limit (the forecaster's own chance of this, stated with the estimate: 10%); at least 13-fold (1.12 log units) between middle value and limit.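

Bromo in place of hydrogen on an aromatic carbon, para to a large group, is far from a neutral change in this assay, with an at least 40-fold higher number from compound 2 to compound 4 (1.60 log units; beyond the scatter). Going by these compounds alone, this position had so far been seen only through the fluoro of compound 3, and a single added heavy atom here now shifts the dose as strongly as the change on the carbonyl carbon did, while the fluoro entries stay well short of that: the several entries of compound 3 in this assay, 8.8 mg/kg; 28 mg/kg; 49 mg/kg (3 entries). Compound 1 and compound 4 both stand at a limit, so the step between them cannot be read: the limit of > 200 mg/kg in this assay, at which 2 of the 4 values shown sit.

The compounds shown leave open whether chloro, methyl or methoxy at this place would behave like fluoro or like bromo. With three separate entries for compound 3, the fluoro case also offers no single figure to set against hydrogen.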